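Notes on aromatic substituent changes in the series

The source may report more compounds than this note shows. Statements on the series, on what has been measured and on what is new or still open speak of the compounds shown alone.

Compound 1 `CN1O[C@H](n2cc(-c3ccccc3)nn2)C[C@@H]1CO` and compound 2 `COc1ccc(-c2cn([C@@H]3C[C@H](CO)N(C)O3)nn2)cc1` share one core and differ only at an aromatic carbon. In a functional assay on FTC-133 cells (Homo sapiens) for cytotoxicity, read by MTT assay, with a stated time of 24 h (on this read-out higher numbers stand for weaker inhibition and lower numbers for stronger inhibition), compound 1 gives 6330 nM, and compound 2 gives 6480 nM. The step of a 1.0-fold higher number from compound 1 to compound 2 (0.01 log units; within the scatter) shows that methoxy in place of hydrogen on that carbon lies within the scatter. Of the two numbers shown, compound 2 holds the nominally higher one, yet its distance from compound 1 is within the scatter, so the two cannot be told apart on this read-out.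

Compound 3 `CCCCCc1ccc(-c2cn([C@@H]3C[C@H](CO)N(C)O3)nn2)cc1` is not yet measured. It differs from compound 2 by pentyl in place of methoxy on an aromatic carbon. Within the data shown here, the only measured step on this aromatic carbon is a 1.0-fold higher number from compound 1 to compound 2 (0.01 log units; within the scatter), which was flat; no measured step covers pentyl itself, so the size of its effect is unknown. The step of a 1.1-fold lower number from compound 2 to compound 3 (0.03 log units; within the scatter) is expected to be small, with no direction beyond the scatter. For compound 3 in this assay the estimate is 6000 nM, in a range from 2000 nM to 18000 nM. The range is kept wide; nothing measured tests pentyl.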

Compound 3, half-maximal inhibitory concentration: 4490 nM
The estimate for compound 3 lay 1.3-fold (0.13 log units) above the measured number; the range from low to high includes it.
By their numbers in this assay, from the lowest: compounds 3, 1 and 2 (each within the scatter of the next).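

Notes on the pentyl result

At this aromatic carbon, para to a large group, pentyl in place of methoxy gives a 1.4-fold lower number from compound 2 to compound 3 (0.16 log units; within the scatter) in this assay and pentyl in place of hydrogen gives a 1.4-fold lower number from compound 1 to compound 3 (0.15 log units; within the scatter) on the same read-out. The earlier pair tested only methoxy against hydrogen, whereas these steps extend the comparison to a chain of five carbons with no hydrogen-bond acceptor, and both still lie within the scatter, so hydrogen, methoxy and pentyl cannot be told apart across compound 1, compound 2 and compound 3. No supporting data are available to account for this flat result at the position.

On these data alone, whether an amine, a carboxylic acid or a chain longer than pentyl on this aromatic carbon would give a step beyond the scatter remains open. The three compounds differ at this carbon alone, and whether a change elsewhere on the shared core would separate from the scatter is also unresolved.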